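The source may report more compounds than this note shows. Statements on the series, on what has been measured and on what is new or still open speak of the compounds shown alone.

In a toxicity assay on THP-1 cells (Homo sapiens) for inhibition (a lower number here means that less compound is tolerated, a higher number that more compound is tolerated), three compounds have been examined so far, and none of them yields a number. Compound 1 `Cn1c(-c2cccc([N+](=O)[O-])c2)cnc1NC(=O)c1ccc(F)cc1` reaches only a limit of the assay, giving > 50000 nM. Compound 2 `COc1ccc(-c2cnc(NC(=O)c3ccco3)n2C)cc1` also returns a limit, with > 100000 nM. Compound 3 `COc1ccc(-c2nc3ncc(-c4ccc(F)cc4)cc3[nH]2)cc1` likewise stops at a limit, > 100000 nM. For the measured compounds named here, compound 2 therefore stands at the limit of > 100000 nM in this assay, at which 2 of the 3 values shown sit, while the remaining value rests at the limit of > 50000 nM in this assay, at which 1 of the 3 values shown sits; no compound in this set gives a value within the measured range, so no step between measured compounds can be read.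

Compound 4 `COc1ccc(-c2cnc(NC(=O)c3ccccc3)n2C)cc1` has not yet been examined in this assay. It differs from compound 2 in a single place: phenyl in place of furan-2-yl on a carbonyl carbon. Going by the values given here, nothing measured here separates a furan-2-yl from a phenyl on that carbonyl carbon, and all three values so far are limits rather than numbers. The expected change a number no higher from compound 2 to compound 4 (the limit leaves the size open) is none beyond the scatter, in either direction. Compound 4 is estimated to give 100000 nM in this assay, with a range from 40000 nM to 250000 nM, and a limit rather than a number is again considered the most likely report.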

Compound 4, half-maximal cytotoxic concentration: > 100000 nM
Compound 4 gave a limit, no number; the forecaster's own chance of this, stated with the estimate: 80%; the middle value lies on the limit itself.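

For the compounds shown here, compound 2 and compound 4 both stop at a limit in this assay, and no step between them can be read. The compounds shown leave open whether phenyl and furan-2-yl on a carbonyl carbon differ at all in this assay, and none of the four gives a number.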